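The source may report more compounds than this note shows. Statements on the series, on what has been measured and on what is new or still open speak of the compounds shown alone.

In a functional assay on DU-145 cells (Homo sapiens) for inhibition, read by trypan blue exclusion, with a stated time of 96 h (a higher number here means a weaker inhibitor of growth, a lower number a stronger inhibitor of growth), the measured compounds give:

- Compound 1 `O=C(O)c1ccc(C(=O)/C(=C\c2ccc(Cl)c([N+](=O)[O-])c2)SCc2ccc(F)cc2)cc1`: 1000 nM
- Compound 2 `O=C(O)c1ccc(C(=O)/C(=C\c2ccc(Cl)c([N+](=O)[O-])c2)SCc2ccc(Br)cc2)cc1`: 500 nM
- Compound 3 `O=C(O)c1ccc(C(=O)/C(=C\c2ccc(Cl)c([N+](=O)[O-])c2)S(=O)(=O)Cc2ccc(Br)cc2)cc1`: 25000 nM

Compound 3 has the highest number of the three, which makes it the weakest growth inhibitor here. Compound 4 `O=C(O)c1ccc(C(=O)/C(=C\c2ccc(Cl)c([N+](=O)[O-])c2)SCc2ccc(Cl)cc2Cl)cc1` differs from it by one change: (2,4-dichlorobenzyl)sulfanyl in place of (4-bromobenzyl)sulfonyl on a double-bonded chain carbon bound to a carbonyl carbon and a double-bonded chain carbon. Going by the values given here, two measured steps bear on this, a 25-fold higher number from compound 1 to compound 3 (1.40 log units; beyond the scatter) and a 50-fold higher number from compound 2 to compound 3 (1.70 log units; beyond the scatter), both large and both leading to the sulfonyl compound. Among the compounds with values here, the halogen swap, a 2.0-fold lower number from compound 1 to compound 2 (0.30 log units; within the scatter), stayed within the scatter, though no dichlorinated compound has been measured. Compound 4 carries a sulfanyl group, as do compound 1 at 1000 nM and compound 2 at 500 nM, so a large drop in this assay is expected: a 36-fold lower number from compound 3 to compound 4 (1.55 log units; beyond the scatter). For compound 4 the estimated value is 700 nM, with an expected range from 200 nM to 2500 nM.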

Compound 4, concentration for 50% growth inhibition in the DU-145 assay: 1000 nM
The estimate for compound 4 lay 1.4-fold (0.15 log units) below the measured number; the range from low to high includes it.
By their numbers in the DU-145 assay, from the lowest: compounds 2, 1 and 4 (each within the scatter of the next); then compound 3.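

In the DU-145 assay the result is a 25-fold lower number from compound 3 to compound 4 (1.40 log units; beyond the scatter) and puts a third sulfanyl compound far from the sulfonyl compound. Against the other two sulfanyl compounds, the ring change gives a 2.0-fold higher number from compound 2 to compound 4 (0.30 log units; within the scatter) and no change at the digits printed from compound 1 to compound 4 (within the scatter) with no separation beyond the scatter, so 2,4-dichlorobenzyl fits this place as well as the 4-bromobenzyl and 4-fluorobenzyl groups do.

On these data alone, how a sulfoxide link or an amine on the benzyl ring would behave here stays open. In a physicochemical assay for solubility (a lower number here means a less soluble compound, a higher number a more soluble compound), compound 3 gives < 1000 ug/mL, which is a limit of the assay and not a number. In the physicochemical assay compound 4 gives < 1000 ug/mL, which is also a limit of the assay and not a number. The step in the physicochemical assay cannot be read, since both compounds sit at a limit: the limit of < 1000 ug/mL in the physicochemical assay, at which 2 of the 2 values shown sit.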